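The source may hold more compounds than are shown below. What is called first, only, known or untested is meant among the compounds shown, and "the series" means these compounds.

Of the compounds shown here, three that share one core have been tested in a functional assay on MCF7 cells (Homo sapiens) for antiproliferative activity, read by sulforhodamine B assay, with a stated time of 48 h; a lower number here means a stronger inhibitor, a higher number a weaker inhibitor. Compound 1 `CCCCCc1ccc(NS(=O)(=O)c2ccc(N3CCNC3=O)cc2)cc1` carries a pentyl group on an aromatic carbon. In this assay compound 1 reaches only the limit of the assay, > 1000 nM, and not a number. Compound 2 `O=C1NCCN1c1ccc(S(=O)(=O)Nc2ccc(Br)cc2)cc1` carries bromo in that place, and in this assay compound 2 gives 240 nM. Compound 3 `CC(C)(C)c1ccc(NS(=O)(=O)c2ccc(N3CCNC3=O)cc2)cc1` carries tert-butyl there. In this assay compound 3 also stops at the limit of the assay, > 1000 nM, not a number. Compound 3 therefore stands at the weak end of the measured set, at the limit of > 1000 nM in this assay, at which 2 of the 3 values shown sit.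

Two steps can be read: an at least 4.1-fold lower number from compound 1 to compound 2 (0.61 log units; beyond the scatter) and an at least 4.1-fold higher number from compound 2 to compound 3 (0.61 log units; beyond the scatter). The step that the two limits leave unreadable from compound 1 to compound 3 cannot be read, since both of its values are limits. Within these three compounds, the two alkyl groups, pentyl and tert-butyl, leave the compound at the limit, while bromo brings it to a measurable number.

Compound 4 `CCCCc1ccc(NS(=O)(=O)c2ccc(N3CCNC3=O)cc2)cc1` has not yet been measured. It differs from compound 3 by butyl in place of tert-butyl on an aromatic carbon. Butyl is a third alkyl group of the same size as tert-butyl, and the two alkyl-bearing compounds, compound 1 and compound 3, both stop at the limit. The expected step that the limit leaves unreadable from compound 3 to compound 4 is therefore none beyond the scatter. Compound 4 is expected to give about 2500 nM, within a range of 800 nM to 10000 nM, most likely again only as a limit.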

Compound 4, half-maximal inhibitory concentration: 770 nM
Compound 4: the middle estimate sits 3.2-fold (0.51 log units) above what was measured, outside the stated range (below it).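

Butyl and tert-butyl have the same atoms, joined differently, yet compound 4 gives a true number in this assay, so an alkyl group on this aromatic carbon does not by itself leave the compound at the limit. How large the gain is stays unproven, and neither floor clears the scatter: there is an at least 1.2-fold lower number from compound 3 to compound 4 (0.11 log units; that floor lies within the scatter) and also an at least 1.2-fold lower number from compound 1 to compound 4 (0.11 log units; that floor lies within the scatter) for the shortening of pentyl to butyl. Bromo nevertheless keeps a real lead over butyl at this position, seen as a 3.2-fold higher number from compound 2 to compound 4 (0.51 log units; beyond the scatter) between the two compounds that have true numbers.

On these data alone, the true values of compound 1 and compound 3 remain hidden, so how far either one lies from compound 4 cannot be read: the limit of > 1000 nM in this assay, at which 2 of the 4 values shown sit. Also open is whether the trend with chain shape and length holds for a shorter chain such as ethyl or a longer chain such as hexyl, and what an amine or a carboxylic acid would give in this same place.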